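The source may hold more compounds than are shown below. What is called first, only, known or untested is meant among the compounds shown, and "the series" means these compounds.

Measured so far:
- Compound 1, `Cc1c(C(=O)Nc2c(F)cc(-c3cccc(F)c3)cc2F)nc2ccc(F)cc2c1O`: 22.3%
- Compound 2, `CCOc1ccc2nc(C(=O)Nc3c(F)cc(-c4cccc(F)c4)cc3F)c(C)c(O)c2c1`: 1.56%

For the measured compounds named here, in a functional assay on Hep 3B2 cells (Homo sapiens) for antiproliferative activity, read by MTT assay, with a stated time of 24 h, tested at 3.7 ug/mL (on this read-out higher numbers stand for a stronger effect at the one concentration tested and lower numbers for a weaker effect), compound 2 stands lowest of the two numbers; its nearest neighbour is compound 1, reached by a number 20.7 percentage points lower from compound 1 to compound 2 (beyond the scatter), the only step measured. Compound 3, `Cc1c(C(=O)Nc2c(F)cc(-c3cccc(F)c3)cc2F)nc2ccc(OC(F)(F)F)cc2c1O`, differs from compound 2 by trifluoromethyl in place of ethyl on an oxygen on an aromatic ring. Going by the values given here, no measured step covers this change; the one step, from fluoro to ethoxy, ran downward, and neither of its ends matches trifluoromethoxy. The expectation for compound 3 is therefore a step of a number 6.4 percentage points higher from compound 2 to compound 3 (within the scatter), not beyond the scatter. Compound 3 is estimated at 8%, within 0% to 25%.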

Compound 3, a percentage reported as inhibition, at one concentration (the size of the read-out at that concentration, not a potency): 26.4%
For compound 3 the middle estimate is 18.4 percentage points below the measured one, and the stated range ends below it.
By their numbers in this assay, from the lowest: compound 2; then compounds 1 and 3 (each within the scatter of the next).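

Changing the ethyl on this oxygen to trifluoromethyl gives a number 24.8 percentage points higher from compound 2 to compound 3 (beyond the scatter) in this assay and shows that the low number of compound 2 does not hold for every group on this oxygen. Trifluoromethoxy in place of fluoro gives a number 4.1 percentage points higher from compound 1 to compound 3 (within the scatter) and so does not separate these two groups. Nothing on hand explains the difference between ethyl and trifluoromethyl here.

From the compounds shown here alone, whether the low number belongs to ethoxy alone stays open; methoxy, a longer alkoxy chain or an amine in this place would test that. Each reading shows only a stronger or weaker effect at the one concentration tested and leaves the effect at other concentrations open.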